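From an aromatic substituent to an arylamino group

A few compounds are considered here, and "the series" means these few. Any claim that something is new, unique, unknown or untested is made for them only; others in the source may bear on it.

Measured in a functional assay on HeLa cells (Homo sapiens) for antiproliferative activity, read by MTT assay, with a stated time of 72 h; on this read-out higher numbers stand for weaker inhibition and lower numbers for stronger inhibition:
Compound 1 `COc1ccccc1-c1c(C(=O)c2cc(OC)c(OC)c(OC)c2)sc2ccccc12`: 5000 nM
Compound 2 `CCOc1ccc(-c2c(C(=O)c3cc(OC)c(OC)c(OC)c3)sc3ccccc23)cc1`: 3000 nM

Within the data shown here, compound 2 cannot be separated from the only other measured compound. Among the measured compounds shown here, the single measured step is a 1.7-fold lower number from compound 1 to compound 2 (0.22 log units; within the scatter).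

Compound 3 `COc1cc(C(=O)c2sc3ccccc3c2Nc2ccc(Cl)cc2)cc(OC)c1OC` has (4-chlorophenyl)amino in place of 4-ethoxyphenyl on an aromatic carbon. For the measured compounds named here, that single step exchanged one substituted phenyl group for another, and no measured compound carries an amino group at this place, so it bears on the new change only loosely. It gives no direction, and no shift beyond the scatter is expected in this assay, although the uncertainty is wide. The estimated step is no change at the digits printed from compound 2 to compound 3 (within the scatter). Compound 3 is expected at 3000 nM, with an estimated range of 500 nM to 10000 nM.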

Compound 3, half-maximal inhibitory concentration: 3700 nM
Compound 3: middle estimate off by 1.2-fold (0.09 log units), on the low side; the measured number falls inside the stated range.
By their numbers in this assay, from the lowest: compounds 2, 3 and 1 (each within the scatter of the next).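

With the linking amino group in place of a directly attached phenyl ring, this carbon of the five-membered aromatic ring now carries a hydrogen-bond donor, yet in this assay the read-out stays within the scatter, with a 1.2-fold higher number from compound 2 to compound 3 (0.09 log units; within the scatter) and a 1.4-fold lower number from compound 1 to compound 3 (0.13 log units; within the scatter). The three compounds therefore cannot be ranked, and this position accepts either kind of attachment at this level of activity. No independent evidence bears on this result.

The step to compound 3 introduces the amino link and the chlorine together, so the part played by each remains unresolved. Also open, as far as these compounds go, is how this assay would read with a smaller or differently built group on the same carbon, such as a benzylamino group, a morpholine ring or an unsubstituted amine.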